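The source may report more compounds than this note shows. Statements on the series, on what has been measured and on what is new or still open speak of the compounds shown alone.

Compound 2 `COc1cc(-c2cc(/C=C/C(=O)c3ccc(N)cc3)[nH]n2)cc(OC)c1OC` gives the lowest of the three numbers in a functional assay on RPMI-8226 cells (Homo sapiens) for inhibition, read by sulforhodamine B assay, with a stated time of 48 h (on this read-out lower numbers stand for stronger inhibition of growth and higher numbers for weaker inhibition of growth), at 470 nM, though every neighbour lies within the scatter of it. Compound 3 `COc1cc(-c2cc(/C=C/C(=O)c3ccc(Cl)c(Cl)c3)[nH]n2)cc(OC)c1OC` gives 530 nM in this assay. Compound 1 `COc1ccc(-c2cc(/C=C/C(=O)c3ccc(N)cc3)[nH]n2)cc1` differs from compound 2 in the methoxy pattern of the aryl ring, and in this assay compound 1 gives 600 nM. Compound 4 `COc1ccc(-c2cc(/C=C/C(=O)c3ccc(N)cc3)[nH]n2)cc1OC` is obtained from compound 2 by hydrogen in place of methoxy on an aromatic carbon. For the measured compounds named here, the only step between measured compounds that differ in one place, a 1.1-fold higher number from compound 2 to compound 3 (0.05 log units; within the scatter), concerns the other end of the molecule and is within the scatter. Going by the values given here, no measured step removes a methoxy group from the aryl ring, but the values of compound 1 and compound 2 show that a different methoxy pattern there leaves the number within the scatter. Compound 4 is therefore expected to show no change beyond the scatter, a step of a 1.1-fold higher number from compound 2 to compound 4 (0.05 log units; within the scatter). The estimated value of compound 4 in this assay is 530 nM, in the range 300 nM to 950 nM.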

Compound 4, concentration for 50% growth inhibition: 1280 nM
Estimate against measurement, compound 4: 2.4-fold (0.38 log units) below; the whole stated range lies below it.
By their numbers in this assay, from the lowest: compounds 2, 3 and 1 (each within the scatter of the next); then compound 4.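

In this assay the methoxy group on this aromatic carbon, ortho to a methoxy group and meta to a large group, proves to count: hydrogen in its place gives a 2.7-fold higher number from compound 2 to compound 4 (0.44 log units; beyond the scatter), a modest step beyond the scatter. Methoxy in place of hydrogen on an aromatic carbon gives a 2.1-fold higher number from compound 1 to compound 4 (0.33 log units; beyond the scatter), so compound 4 stands apart from both of its neighbours. Among these compounds the number of methoxy groups alone therefore does not set the order, and the outcome of each change depends on which other methoxy groups the ring carries.

Nothing here gives a reason for these steps. On these data alone, it remains open whether a hydroxyl or an ethoxy group on this carbon would side with compound 2 or with compound 4.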